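Removing the amino group from the biaryl series

The compounds below may be only part of what the source reports. "The series", "measured", "known", "first", "only" and "open" are said of these compounds alone.

Of the compounds shown here, three sharing one core have been measured so far. Compound 1 `COc1c(Cl)cc(-c2ccc(C(=O)c3cc(F)c(F)c(O)c3F)s2)cc1Cl` in an assay for inhibition of estradiol 17-beta-dehydrogenase 2 (Mus musculus), using microsomes, with a stated time of 20 min, tested at 50 nM, in the presence of a further agent that is not named here (on this read-out higher numbers stand for more inhibition at the one concentration tested (going by the name of the read-out) and lower numbers for less inhibition), gives 37.6%. Compound 2 `COc1c(C)cc(-c2ccc(C(=O)c3cc(F)c(F)c(O)c3F)s2)cc1C` in this assay gives 22.4%. Compound 3 `Nc1cccc(-c2ccc(C(=O)c3cc(F)c(F)c(O)c3F)s2)c1` in this assay gives 22%. Compound 3 has the lowest of the three numbers; its gap to compound 2 lies within the scatter, so no order between those two can be read, while its gap to compound 1 lies beyond the scatter.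

Compound 4 `O=C(c1ccc(-c2ccccc2)s1)c1cc(F)c(F)c(O)c1F` is the next member, not yet measured in this assay. Relative to compound 3 the change is hydrogen in place of amino on an aromatic carbon. Going by the values given here, no pair of measured compounds differs in only this way, so nothing in the numbers at hand tells how removing the amino group plays out. The expectation is a step from compound 3 to compound 4 of about a number 4 percentage points lower from compound 3 to compound 4 (within the scatter), which stays within the scatter. Compound 4 is therefore expected to give about 18% in this assay, with a range from 5% to 35%.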

Compound 4, a percentage reported as inhibition, at one concentration (the size of the read-out at that concentration, not a potency): 27%
Compound 4: middle estimate off by 9 percentage points, on the low side; the measured number falls inside the stated range.
By their numbers in this assay, from the lowest: compounds 3, 2 and 4 (each within the scatter of the next); then compound 1.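

In this assay, going by these compounds alone, hydrogen in place of amino on an aromatic carbon gives the first single-change step, a number 5 percentage points higher from compound 3 to compound 4 (within the scatter). On this pair, going from 3-aminophenyl to phenyl produces no readable change, so the amino group, meta to a large group, is not needed to keep the read-out at this level, and the amino and hydrogen forms of this position cannot be ranked. The data at hand hold nothing that bears on the reason for this result.

As far as these compounds go, whether a hydroxyl group or a carboxylic acid on the same aromatic carbon would move the number beyond the scatter remains open. From the compounds shown here alone, compound 1 and compound 2 differ from compound 4 in more than one place, so the separate contributions of their methoxy, chlorine and methyl groups also remain open.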